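Swapping the Ester Aryl Group on Two Related Cores

The source may report more compounds than this note shows. Statements on the series, on what has been measured and on what is new or still open speak of the compounds shown alone.

Compound 1 `COc1cccc(C(=O)Oc2cc3c(cc2C)[C@@H](C(C)C)CC=C3C)c1` and compound 2 `CC1=CC[C@H](C(C)C)c2cc(C)c(OC(=O)c3ccc([N+](=O)[O-])cc3)cc21` share one core and differ only in the aryl group on the ester: 4-nitrophenyl in place of 3-methoxyphenyl on a carbonyl carbon. In a functional assay on PC-3 cells (Homo sapiens) for antiproliferative activity, read by sulforhodamine B assay, with a stated time of 48 h, tested at 50 uM (on this read-out higher numbers stand for more inhibition at the one concentration tested (going by the name of the read-out) and lower numbers for less inhibition), compound 1 gives 16.3%, while compound 2 gives 36.7%, which is a number 20.4 percentage points higher from compound 1 to compound 2 (beyond the scatter). Compound 3 `COc1cccc(C(=O)Oc2cc3c(C)ccc(C(C)C)c3cc2C)c1` carries the same 3-methoxyphenyl ester on a second core; the difference between the two cores is not broken down here. In this assay compound 3 gives 12.5%, close to compound 1. Compound 4 `Cc1cc2c(C(C)C)ccc(C)c2cc1OC(=O)c1ccc([N+](=O)[O-])cc1` arises from compound 3 by the same change: 4-nitrophenyl in place of 3-methoxyphenyl on a carbonyl carbon. Resting on the single earlier step, the expected step is a number 20.5 percentage points higher from compound 3 to compound 4 (beyond the scatter). Compound 4 is therefore estimated at 33%, with a likely range from 16% to 50%.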

Compound 4, a percentage reported as inhibition, at one concentration (the size of the read-out at that concentration, not a potency): 100%
Estimate against measurement, compound 4: 67 percentage points below; the whole stated range lies below it.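

In this assay, putting 4-nitrophenyl in place of 3-methoxyphenyl on the second core gives a number 87.5 percentage points higher from compound 3 to compound 4 (beyond the scatter). The direction of the change carries over between the two cores, but its size does not: the same change on two cores in this assay, a number 20.4 percentage points higher (beyond the scatter) from compound 1 to compound 2 and a number 87.5 percentage points higher (beyond the scatter) from compound 3 to compound 4, 67.1 percentage points apart, beyond the scatter of two such steps. Two pairs of compounds cannot explain why the size of the step depends on the core, and they cannot predict the step on a further core; each number is also a reading at one concentration, not a potency.

The compounds shown leave open whether a nitrile or an amine in place of the nitro group would also give a larger step on the second core than on the first. They also leave open whether an amide in place of the ester would keep the high reading of compound 4.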